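Notes on compound 4: 1-benzofuran-2-yl replacing thiophen-2-yl

A few compounds are considered here, and "the series" means these few. Any claim that something is new, unique, unknown or untested is made for them only; others in the source may bear on it.

Compound 3 `CNc1ncnc2c1c(-c1cccs1)cn2[C@@H]1O[C@H](CO)[C@@H](O)[C@H]1O` gives > 20000 nM in a functional assay on CCRF-CEM cells (Homo sapiens), read by MTT assay, with a stated time of 72 h (a higher number here means a weaker inhibitor, a lower number a stronger inhibitor), and this is a limit, not a number. That places compound 3 at the limit of > 20000 nM in this assay, at which 1 of the 3 values shown sits. The change to compound 4 `CNc1ncnc2c1c(-c1cc3ccccc3o1)cn2[C@@H]1O[C@H](CO)[C@@H](O)[C@H]1O` is 1-benzofuran-2-yl in place of thiophen-2-yl on an aromatic carbon.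

For the measured compounds named here, one measured step bears directly on this position. Compound 2 `CNc1ncnc2c1c(-c1ccco1)cn2[C@@H]1O[C@H](CO)[C@@H](O)[C@H]1O` gives 180 nM in this assay, and the move away from it is an at least 110-fold higher number from compound 2 to compound 3 (2.04 log units; beyond the scatter), with thiophen-2-yl in place of furan-2-yl on an aromatic carbon. This large step shows that a change at this position alone can shift the read-out strongly. Compound 1 `COc1ncnc2c1c(-c1cc3ccccc3o1)cn2[C@@H]1O[C@H](CO)[C@@H](O)[C@H]1O` also bears 1-benzofuran-2-yl and gives 5370 nM, which is the closest guide to the level of compound 4.

A step towards a lower number in this assay is therefore expected, though the limit on compound 3 leaves its size open. The expected step is estimated as an at least 4.4-fold lower number from compound 3 to compound 4 (0.64 log units; beyond the scatter). Compound 4 is not expected to reach the level of compound 2 at 180 nM. The estimate for compound 4 is 4500 nM, with an expected range of 1000 nM to 18000 nM.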

Compound 4, half-maximal inhibitory concentration: > 20000 nM
Compound 4: only a limit was reported (the forecaster's own chance of this, stated with the estimate: 15%); at least 4.4-fold (0.64 log units) between middle value and limit.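

In this assay compound 4 gives a limit and not a number, the same limit as compound 3, so the step between these two cannot be read and any order between thiophen-2-yl and 1-benzofuran-2-yl stays unknown: the limit of > 20000 nM in this assay, at which 2 of the 4 values shown sit.

With methylamino held, 1-benzofuran-2-yl in place of furan-2-yl gives an at least 110-fold higher number from compound 2 to compound 4 (2.04 log units; beyond the scatter), so among the three groups shown with methylamino at this position, only furan-2-yl gives a measured number. With 1-benzofuran-2-yl held, methylamino in place of methoxy gives an at least 3.7-fold higher number from compound 1 to compound 4 (0.57 log units; beyond the scatter), so the level of the 1-benzofuran-2-yl group depends on the second site of change and does not carry over from one partner to the other.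

The compounds shown leave open whether the measured level with methylamino is tied to furan-2-yl alone or would also hold for a close relative such as furan-3-yl or for a phenyl group. They also leave open whether methoxy would give a measured number with furan-2-yl or thiophen-2-yl, and how a plain amino group would behave at the second site.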